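From Compound 2 to Compound 3: Trifluoromethyl Becomes Chloro

The source may report more compounds than this note shows. Statements on the series, on what has been measured and on what is new or still open speak of the compounds shown alone.

Of the compounds shown here, two sharing one core have been measured in a functional assay on Malme-3M cells (Homo sapiens) for inhibition, read by sulforhodamine B assay, with a stated time of 48 h; a lower number here means a stronger inhibitor of growth, a higher number a weaker inhibitor of growth. Compound 1 `COc1cc2cc(Oc3ccc(NC(=O)Nc4cccc(C(F)(F)F)c4)cc3)c(C)nc2cc1OC` gives 1710 nM. Compound 2 `COc1cc2cc(Oc3ccc(NC(=O)Nc4ccc(Cl)c(C(F)(F)F)c4)cc3)c(C)nc2cc1OC` gives 1330 nM. Among the measured compounds shown here, the only measured step, a 1.3-fold lower number from compound 1 to compound 2 (0.11 log units; within the scatter), shows how little one added chloro moved the number. For the measured compounds named here, on the numbers so far, compound 2 gives the lower of the two values, yet its gap to compound 1 lies within the scatter, so no order between them can be claimed.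

Compound 3 `COc1cc2cc(Oc3ccc(NC(=O)Nc4ccc(Cl)c(Cl)c4)cc3)c(C)nc2cc1OC` has not yet been measured. It differs from compound 2 in one place: chloro in place of trifluoromethyl on an aromatic carbon. Going by the values given here, no measured step makes this same exchange. An expectation for this assay can rest only on the step from compound 1 to compound 2, which changed a group on the same ring and stayed within the scatter. The step expected for compound 3 in this assay is a 1.1-fold higher number from compound 2 to compound 3 (0.05 log units; within the scatter). Compound 3 is therefore expected to give about 1500 nM in this assay, within a range from 600 nM to 3800 nM.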

Compound 3, concentration for 50% growth inhibition: 3020 nM
Beside the measured number, compound 3's estimate is 2.0-fold (0.30 log units) below it, within the range that was stated.
By their numbers in this assay, from the lowest: compounds 2, 1 and 3 (each within the scatter of the next, the first and the last beyond it).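

In this assay, among the compounds shown here, putting chloro in place of trifluoromethyl on this aromatic carbon, ortho to a chloro group, gives a 2.3-fold higher number from compound 2 to compound 3 (0.36 log units; beyond the scatter) and so is the first step here to lie beyond the scatter, which shows that the group at this position can shift the number, though only modestly, and that the shift is towards weaker inhibition of growth. The wider comparison, 3,4-dichlorophenyl in place of 3-(trifluoromethyl)phenyl on an amide-type nitrogen, gives a 1.8-fold higher number from compound 1 to compound 3 (0.25 log units; within the scatter) and allows no order between those two compounds, so the loss is visible only against compound 2, the compound that carries both groups on its ring. Nothing available here explains why these two groups differ at this position.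

From the compounds shown here alone, it remains open how this position would respond to quite different groups, such as a nitrile, an amine or a carboxylic acid, since trifluoromethyl and chloro are the only two compared here. Going by these compounds, it is also open whether the same exchange would give a step of similar size without the other chloro group on the ring, or on another core.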